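The source may hold more compounds than are shown below. What is called first, only, known or untested is meant among the compounds shown, and "the series" means these compounds.

Measured compounds in a functional assay on DU-145 cells (Homo sapiens) for inhibition; a lower number here means a stronger inhibitor, a higher number a weaker inhibitor:
compound 1 `Oc1ccc(-c2cc(-c3ccccc3F)cc(-c3cccc(O)c3)n2)cc1`: 3160 nM
compound 2 `Oc1ccc(-c2cc(-c3ccc(F)cc3)cc(-c3cccc(O)c3)n2)cc1`: 15200 nM
compound 3 `Oc1cccc(-c2cc(-c3ccccc3C(F)(F)F)cc(-c3ccccc3O)n2)c1`: 7250 nM

Among these three numbers compound 3 stands second highest. Its nearest neighbour is compound 2, whose number is higher, and the furthest is compound 1, whose number is lower; both gaps lie beyond the scatter, so compound 3 is a weaker inhibitor than compound 1 and a stronger one than compound 2.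

The step to compound 4 `Oc1ccc(-c2cc(-c3ccccc3C(F)(F)F)cc(-c3cccc(O)c3)n2)cc1` rearranges the same atoms: 4-hydroxyphenyl in place of 2-hydroxyphenyl on an aromatic carbon. Going by the values given here, the only measured step, a 4.8-fold higher number from compound 1 to compound 2 (0.68 log units; beyond the scatter), concerns a different ring of the shared core and moves a fluorine rather than a hydroxyl, so it does not bear directly on this change. What the data do show is that compound 1, which carries the 4-hydroxyphenyl and 3-hydroxyphenyl pair, gives the lowest number of the three, while compound 3 with the 2-hydroxyphenyl gives a higher one; these two compounds also differ in their third aryl group, so the comparison is only suggestive.

On that basis a modest step toward a lower number is expected, a 1.8-fold lower number from compound 3 to compound 4 (0.26 log units; within the scatter), with wide uncertainty. Compound 4 is therefore estimated at 4000 nM in this assay, within a range from 1500 nM to 12000 nM.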

Compound 4, half-maximal inhibitory concentration: 2750 nM
Compound 4: middle estimate off by 1.5-fold (0.16 log units), on the high side, and the stated range covers the measured number.
By their numbers in this assay, from the lowest: compounds 4 and 1 (each within the scatter of the next); then compound 3; then compound 2.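

In this assay, the step of a 2.6-fold lower number from compound 3 to compound 4 (0.42 log units; beyond the scatter) shows that the position next to the ring nitrogen responds to where the hydroxyl sits on its phenyl ring, even though the atoms are unchanged and the 4-hydroxyphenyl gives the lower number. The third aryl group can now also be read with this hydroxyl arrangement held fixed: trifluoromethyl in place of fluoro gives a 1.1-fold lower number from compound 1 to compound 4 (0.06 log units; within the scatter), so those two compounds cannot be told apart, whereas 2-(trifluoromethyl)phenyl in place of 4-fluorophenyl gives a 5.5-fold lower number from compound 2 to compound 4 (0.74 log units; beyond the scatter). Within these compounds, the two groups substituted at the 2-position of that aryl ring stand together and the 4-fluorophenyl stands apart, but nothing available explains either the hydroxyl or the aryl result.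

The compounds shown leave open how a 3-hydroxyphenyl would read at the position next to the ring nitrogen, and whether the gain from the 4-hydroxyphenyl also holds with a 2-fluorophenyl as the third aryl group. From the compounds shown here alone, it also remains open whether the hydroxyl itself matters there, which a methoxy group or an amine in its place would test.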